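Acetylation of a free hydroxy in the lactone series

The source may report more compounds than this note shows. Statements on the series, on what has been measured and on what is new or still open speak of the compounds shown alone.

Among the compounds with values here, two measured compounds make up the series so far. Compound 1 `C=C1C(=O)O[C@]2(C)CC[C@@H]1C[C@H](O)[C@@]1(C)CC[C@H](OC(C)=O)[C@@](C)(CCC2=O)O1` and compound 2 `C=C1C(=O)O[C@]2(C)CC[C@@H]1C[C@H](O)[C@@]1(C)CC[C@H](O1)C(=C)CC[C@H]2OC(C)=O` share a common core, and both have been tested in a functional assay on Doay cells (Homo sapiens) for cytotoxicity, read by MTT assay; a higher number here means that more compound is needed for the effect, a lower number that less compound is needed. In this assay compound 1 reaches only a limit, < 20 ug/mL. In this assay compound 2 likewise reaches only a limit, < 20 ug/mL. Within the data shown here, no numerical step between the two can therefore be given; what is known is the limit of < 20 ug/mL in this assay, at which 2 of the 2 values shown sit.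

Compound 3 `C=C1C(=O)O[C@]2(C)CC[C@@H]1C[C@H](OC(C)=O)[C@@]1(C)CC[C@H](O1)C(=C)CC[C@H]2OC(C)=O` differs from compound 2 in one place: acetyl in place of hydrogen on an oxygen on a saturated carbon. Read one bond further out, the change is hydroxy to acetoxy. Among the measured compounds shown here, with both measured values sitting at a limit, no step in this assay can be drawn on. The expectation is that compound 3 stays near compound 2, with a step from compound 2 to compound 3 of about a step that the limit leaves unreadable from compound 2 to compound 3 in this assay, no more than the scatter. Compound 3 is thus estimated at 10 ug/mL in this assay, within 2 ug/mL to 30 ug/mL.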

Compound 3, concentration for half-maximal effect: < 20 ug/mL
Compound 3 was reported as a limit (the forecaster's own chance of this, stated with the estimate: 60%); the middle value does not contradict the limit.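

Compound 2 and compound 3 both stand as limits in this assay, so no step between them can be read, and the whole series sits at one reported limit: the limit of < 20 ug/mL in this assay, at which 3 of the 3 values shown sit.

The compounds shown leave open whether the change from hydroxy to acetoxy alters the concentration needed at all.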